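From a phenoxymethyl to a 4-nitrophenyl group

The source may report more compounds than this note shows. Statements on the series, on what has been measured and on what is new or still open speak of the compounds shown alone.

In a functional assay on NP14 cells (Homo sapiens) for cytotoxicity, read by MTT assay, with a stated time of 48 h (a lower number here means a stronger inhibitor, a higher number a weaker inhibitor), three compounds sharing one core have been measured. Compound 1 (`C=C1CC[C@@H]2[C@](C)(CO)[C@H](O)CC[C@@]2(C)[C@@H]1CCc1ccoc1`) gives 53300 nM as its number, compound 2 (`C=C1CC[C@@H]2[C@](C)(COC(=O)CC)[C@H](OC(=O)CC)CC[C@@]2(C)[C@@H]1CCc1ccoc1`) gives 94200 nM as its number, and compound 3 (`C=C1CC[C@@H]2[C@](C)(COC(=O)COc3ccccc3)[C@H](O)CC[C@@]2(C)[C@@H]1CCc1ccoc1`) stands lowest of the three at 18600 nM as its number. Compound 4 (`C=C1CC[C@@H]2[C@](C)(COC(=O)c3ccc([N+](=O)[O-])cc3)[C@H](O)CC[C@@]2(C)[C@@H]1CCc1ccoc1`) is still unmeasured. It differs from compound 3 by 4-nitrophenyl in place of phenoxymethyl on a carbonyl carbon. Within the data shown here, one measured step bears on this: a 2.9-fold lower number from compound 1 to compound 3 (0.46 log units; beyond the scatter) is modest and came with (phenoxymethyl)carbonyl in place of hydrogen on an oxygen on a saturated carbon. Compound 4 keeps that carbonyl and one six-membered aromatic ring of carbon only. Among the measured compounds shown here, no measured step shows what exchanging the group on the carbonyl carbon does, so no step beyond the scatter is expected. The expected size is a 1.3-fold higher number from compound 3 to compound 4 (0.13 log units; within the scatter) at the middle of the estimate. Compound 4 is estimated at 25000 nM as the middle value, with 9000 nM as the lower end and 65000 nM as the upper end of the expected range.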

Compound 4, half-maximal inhibitory concentration: 80900 nM
The estimate for compound 4 lay 3.2-fold (0.51 log units) below the measured number, outside the stated range (above it).
By their numbers in this assay, from the lowest: compound 3; then compounds 1, 4 and 2 (each within the scatter of the next).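

In this assay, the group on the carbonyl carbon matters at this position: a 4.3-fold higher number from compound 3 to compound 4 (0.64 log units; beyond the scatter) came with 4-nitrophenyl in place of phenoxymethyl, so the carbonyl and an aromatic ring together do not account for the lower number of compound 3. With (4-nitrophenyl)carbonyl in place of hydrogen on the oxygen, the step is a 1.5-fold higher number from compound 1 to compound 4 (0.18 log units; within the scatter), so the shift seen with (phenoxymethyl)carbonyl does not carry over to this second group. No measurement available here explains why the two groups differ.

The compounds shown leave open whether the difference between compound 3 and compound 4 follows the ether oxygen of phenoxymethyl, the methylene link or the nitro group. A plain phenyl or benzyl group on the same carbonyl carbon, or an amine in place of the nitro group, would help separate these.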